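The source may hold more compounds than are shown below. What is called first, only, known or untested is meant among the compounds shown, and "the series" means these compounds.

In a physicochemical assay for solubility, read by LC-MS, in phosphate buffer, with a stated time of 24 h, at pH 6.8 (on this read-out lower numbers stand for lower solubility and higher numbers for higher solubility), the measured compounds read as follows

Compound 1 (`C[C@H](NC(=O)c1ncccn1)c1ccc(NC(=O)N2CC(c3cccnc3)C2)cc1`) gives 930000 nM
Compound 2 (`C[C@@H](c1ccc(NC(=O)N2CC(c3ccc(N)nc3)C2)cc1)N1Cc2ccccc2C1=O`) gives 220000 nM
Compound 3 (`C[C@H](NC(=O)c1cccc(F)c1)c1ccc(NC(=O)N2CC(c3ccc(N)nc3)C2)cc1`) gives 32000 nM

Compound 3 has the lowest of these three numbers. Compound 4 (`C[C@H](NC(=O)c1ncccn1)c1ccc(NC(=O)N2CC(c3ccc(N)nc3)C2)cc1`) has not been measured yet. It carries pyrimidin-2-yl in place of 3-fluorophenyl on a carbonyl carbon. Among the compounds with values here, only one measured step bears on this, the one that brought in the 3-fluorophenyl group (a 6.9-fold lower number from compound 2 to compound 3 (0.84 log units; beyond the scatter)). Compound 1 also has pyrimidin-2-yl on that carbonyl carbon, though it differs elsewhere, and it stands at 930000 nM as the highest number. A higher number is therefore expected, of similar size to that step (a 7.8-fold higher number from compound 3 to compound 4 (0.89 log units; beyond the scatter)). Compound 4 is estimated at 250000 nM with 90000 nM to 700000 nM as the expected range.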

Compound 4, solubility: 300000 nM
For compound 4 the middle estimate is 1.2-fold (0.08 log units) below the measured one, and the stated range covers the measured number.
By their numbers in this assay, from the lowest: compound 3; then compounds 2 and 4 (each within the scatter of the next); then compound 1.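

With only pyrimidin-2-yl in place of 3-fluorophenyl on the carbonyl carbon, this assay shows a 9.4-fold higher number from compound 3 to compound 4 (0.97 log units; beyond the scatter), so this one change moves the number beyond the scatter. Within the data shown here, the amino group can also be read on its own for the first time: amino in place of hydrogen on an aromatic carbon gives a 3.1-fold lower number from compound 1 to compound 4 (0.49 log units; beyond the scatter). The larger group of compound 2 and the group in compound 4 cannot be told apart, with a 1.4-fold higher number from compound 2 to compound 4 (0.13 log units; within the scatter). Nothing shown gives a reason for these shifts. From the compounds shown here alone, whether pyridin-2-yl or methyl on that carbonyl carbon would read closer to compound 3 or to compound 4 stays open.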